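The source may hold more compounds than are shown below. What is called first, only, known or untested is meant among the compounds shown, and "the series" means these compounds.

Working notes on the series in a physicochemical assay for permeability, using PAMPA; a higher number here means that the compound crosses the layer faster, a lower number that the compound crosses the layer more slowly. Of the compounds shown here, three sharing one core have numbers so far: compound 1 `Cc1ccccc1-c1nc(CN2CCC(C(=O)NCCCN3CCC(C)(C)CC3)CC2)c(C)o1` gives 241 10^-6 cm/s, compound 2 `Cc1ccccc1-c1nc(CN2CCC(C(=O)NCCCN3CCCCC3)CC2)c(C)o1` gives 34.5 10^-6 cm/s, and compound 3 `Cc1ccccc1-c1nc(CN2CCC(C(=O)NCCN3C[C@H](C)C[C@H](C)C3)CC2)c(C)o1` gives 712 10^-6 cm/s. Compound 3 stands highest of the three, and its gaps to both others lie beyond the scatter.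

The next structure is compound 4 `Cc1ccccc1-c1nc(CN2CCC(C(=O)N3CCN(CCN(C)C)CC3)CC2)c(C)o1`, which differs from compound 3 in the group on the carbonyl carbon: a group of 11 heavy atoms (8 carbon, 3 nitrogen; one six-membered non-aromatic ring with 2 hetero atoms) in place of a group of 11 heavy atoms (9 carbon, 2 nitrogen; one six-membered non-aromatic ring with 1 hetero atom), on a carbonyl carbon. The entering group is 4-(2-(dimethylamino)ethyl)piperazin-1-yl.

Within the data shown here, no measured step makes this exact exchange. The nearest evidence comes from changes within the same group: a 7.0-fold lower number from compound 1 to compound 2 (0.84 log units; beyond the scatter), a 3.0-fold higher number from compound 1 to compound 3 (0.47 log units; beyond the scatter) and a 21-fold higher number from compound 2 to compound 3 (1.31 log units; beyond the scatter), the last of these large. This group therefore moves the numbers well beyond the scatter in this series. The entering group carries no methyl groups on its ring, and the closest measured case is compound 2, with its plain piperidin-1-yl, at 34.5 10^-6 cm/s. A large step to a lower number is therefore expected, though the evidence is indirect and the range is kept wide. The expected change is a 24-fold lower number from compound 3 to compound 4 (1.38 log units; beyond the scatter). For compound 4 the estimated value is 30 10^-6 cm/s, with an expected range of 6 10^-6 cm/s to 150 10^-6 cm/s.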

Compound 4, apparent permeability: 14 10^-6 cm/s
Beside the measured number, compound 4's estimate is 2.1-fold (0.33 log units) above it; low and high end bracket the measured number.
By their numbers in this assay, from the lowest: compound 4; then compound 2; then compound 1; then compound 3.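

Among these compounds, on a carbonyl carbon, 4-(2-(dimethylamino)ethyl)piperazin-1-yl in place of the group of compound 3 gives a 51-fold lower number from compound 3 to compound 4 (1.71 log units; beyond the scatter) in this assay and places compound 4 lowest of the four, so the group on this carbon can span a wider range than the earlier compounds showed. The comparison with the plain piperidine compound gives a 2.5-fold lower number from compound 2 to compound 4 (0.39 log units; beyond the scatter) and is modest, so 0 hydrogen-bond donors in the entering group, in place of 1 in the leaving group, did not come with a higher number in either listed step. No measurement on hand bears on what lies behind these steps.

Each step changes several features at once, so the share of the amide hydrogen, the second ring nitrogen and the dimethylamino chain end cannot be separated. The compounds shown leave open how 4-methylpiperazin-1-yl or morpholin-4-yl on the same carbonyl carbon, or an amide that keeps its hydrogen and carries a 2-(dimethylamino)ethyl chain, would read in this assay.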